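The source may report more compounds than this note shows. Statements on the series, on what has been measured and on what is new or still open speak of the compounds shown alone.

Measured so far:
Compound 1 `O=C(COc1cccc(Cl)c1)NC1CCN(Cc2ccc3ccccc3c2)CC1` gives 41 nM in an assay on HEK293 cells for displacement of a labelled ligand from melanin-concentrating hormone receptor 1 (Homo sapiens); on this read-out higher numbers stand for weaker inhibition and lower numbers for stronger inhibition.
Compound 2 `O=C(COc1cccc(Cl)c1)NC1CCN(Cc2ccn(-c3ccccc3)c2)CC1` gives 710 nM in this assay.

Among the measured compounds shown here, of these two numbers, compound 2 holds the highest; the only neighbour, compound 1, sits at a clearly lower value, and the gap between them lies beyond the usual scatter of repeated measurements. For the measured compounds named here, no other measured pair allows a step to be read off.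

The next compound, compound 3 `O=C(COc1cccc(Cl)c1)NC1CCN(Cc2ccn(-c3ccon3)c2)CC1`, carries a single change relative to compound 2: 1,2-oxazol-3-yl in place of phenyl on an aromatic nitrogen. With nothing measured on this kind of change, the size of the step from compound 2 to compound 3 cannot be read from the data. The expectation is a step of a 1.3-fold higher number from compound 2 to compound 3 (0.10 log units; within the scatter), not beyond the scatter. Compound 3 is therefore estimated at 900 nM in this assay, within a range from 300 nM to 2700 nM.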

Compound 3, half-maximal inhibitory concentration: 1500 nM
Beside the measured number, compound 3's estimate is 1.7-fold (0.22 log units) below it; the range from low to high includes it.
By their numbers in this assay, from the lowest: compound 1; then compound 2; then compound 3.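

At this position, on an aromatic nitrogen of a five-membered aromatic ring with 1 nitrogen, replacing phenyl with 1,2-oxazol-3-yl gives a 2.1-fold higher number from compound 2 to compound 3 (0.32 log units; beyond the scatter) in this assay and so a modest loss of inhibition. Among the compounds shown here, this is the first reading of any change at this place, and it shows that the phenyl can give way to a five-membered aromatic ring with 2 hetero atoms at a modest cost, with a measurable value retained. Nothing available explains the direction or the size of this step.

Ring size and hetero atoms change together in this single step, so their contributions cannot be separated. From the compounds shown here alone, a pyridin-3-yl group, a six-membered ring containing nitrogen, or a thiophen-3-yl group, a five-membered ring containing sulfur, would bear on that question, and how either would read here remains open.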